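Thiosemicarbazone variation on a terpenoid core against colon cells

A few compounds are considered here, and "the series" means these few. Any claim that something is new, unique, unknown or untested is made for them only; others in the source may bear on it.

compound 1 `CC1=CC[C@@H]([C@@](C)(O)CCCC(C)(C)NC(=S)NN)CC1`: > 100000 nM
compound 2 `CC1=CC[C@@H]([C@@](C)(O)CCCC(C)(C)NC(=S)N/N=C\c2cccc(Cl)c2)CC1`: 16500 nM

In a functional assay on HT-29 cells (Homo sapiens) for cytotoxicity, read by sulforhodamine B assay (a higher number here means a weaker inhibitor of growth, a lower number a stronger inhibitor of growth), compound 1 gives > 100000 nM, which is a limit of the assay and not a number (the limit of > 100000 nM in this assay, at which 1 of the 2 values shown sits). For the measured compounds named here, compound 2 gives 16500 nM in this assay, the only number among the two values shown. Going by the values given here, the step of an at least 6.0-fold lower number from compound 1 to compound 2 (0.78 log units; beyond the scatter) is the sole measured step, and it concerns the addition of a substituent on the amide-type nitrogen, not the exchange of one such substituent for another. Compound 3 `CC1=CC[C@@H]([C@@](C)(O)CCCC(C)(C)NC(=S)N/N=C(/C)c2ccccc2)CC1` differs from compound 2 by a group of 9 heavy atoms (8 carbon, 1 nitrogen; one six-membered aromatic ring of carbon only) in place of a group of 9 heavy atoms (7 carbon, 1 nitrogen, 1 chlorine; one six-membered aromatic ring of carbon only), on an amide-type nitrogen. Among the compounds with values here, no measured step bears directly on this exchange; the one measured step shows only that a substituent of this kind on the amide-type nitrogen is worth having at all. A step within the usual scatter, in either direction, is therefore expected. Compound 3 is thus estimated at 20000 nM in this assay, with a range from 6000 nM to 70000 nM, meaning an expected step of a 1.2-fold higher number from compound 2 to compound 3 (0.08 log units; within the scatter).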

Compound 3, concentration for total growth inhibition: > 100000 nM
Compound 3 was reported as a limit; the forecaster's own chance of this, stated with the estimate: 15%; middle value at least 5.0-fold (0.69 log units) from the limit.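

The substituent on the amide-type nitrogen cannot be exchanged freely: in this assay, replacing the chlorine-bearing group of compound 2 with the chlorine-free group of compound 3 gives an at least 6.0-fold higher number from compound 2 to compound 3 (0.78 log units; beyond the scatter). Thus, the gain seen on adding a substituent at this nitrogen does not extend to every group of 9 heavy atoms with one six-membered aromatic ring of carbon only. Compound 3 gives > 100000 nM, a limit of the assay and not a number, and its step from compound 1, itself a limit, cannot be read: the limit of > 100000 nM in this assay, at which 2 of the 3 values shown sit.

This exchange removes the chlorine and adds a carbon in one change, and the compounds shown do not separate the two. Going by these compounds, whether a bromine or a methoxy group in place of the chlorine would hold the number of compound 2 also remains open.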